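Benzyl for phenyl on a weakly active pyrimidine series

The source may hold more compounds than are shown below. What is called first, only, known or untested is meant among the compounds shown, and "the series" means these compounds.

Compound 1 `Cc1ccccc1Nc1nc(Nc2ccccc2)ncc1Cl` and compound 2 `Cc1ccccc1Nc1nc(NCc2ccccc2)ncc1Cl` differ by one change, (benzyl in place of phenyl on a nitrogen on an aromatic ring). In a functional assay on MCF7 cells (Homo sapiens) for inhibition, read by CCK-8 assay, with a stated time of 48 h (on this read-out higher numbers stand for weaker inhibition of growth and lower numbers for stronger inhibition of growth), compound 1 gives > 100000 nM, which is a limit of the assay rather than a number. Compound 2 likewise gives > 100000 nM, again a limit. The step that the two limits leave unreadable from compound 1 to compound 2 therefore cannot be sized, because the limit of > 100000 nM in this assay, at which 2 of the 3 values shown sit, hides both ends of it. Compound 3 `CN1CCN(c2ccc(Nc3ncc(Cl)c(Nc4ccccc4)n3)nc2)CC1` carries a different core; how it differs from the core of compound 1 is not broken down here. In this assay, for the measured compounds named here, compound 3 gives 51800 nM, the only number among the three values. Compound 4 `CN1CCN(c2ccc(Nc3ncc(Cl)c(NCc4ccccc4)n3)nc2)CC1` is not yet measured and differs from compound 3 by benzyl in place of phenyl on a nitrogen on an aromatic ring, the same change as that from compound 1 to compound 2, at a place described in identical words. Since the measured example of this change is unreadable, compound 4 is expected to sit close to compound 3, with a step of a 1.3-fold higher number from compound 3 to compound 4 (0.10 log units; within the scatter) in this assay. The estimate for compound 4 is 65000 nM, with a range from 20000 nM to 200000 nM, and the assay may well report only a limit for compound 4.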

Compound 4, concentration for 50% growth inhibition: 17300 nM
Beside the measured number, compound 4's estimate is 3.8-fold (0.57 log units) above it; measured number below the stated range.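

In this assay, benzyl in place of phenyl on a nitrogen on an aromatic ring gives a 3.0-fold lower number from compound 3 to compound 4 (0.48 log units; beyond the scatter), a modest step toward stronger inhibition of growth on the core of compound 3. The same change on the core of compound 1 has no readable size, because compound 1 and compound 2 both stand at a limit rather than a number: the limit of > 100000 nM in this assay, at which 2 of the 4 values shown sit. For the compounds shown here, the result therefore shows that the change can lower the number on one core, but it does not show that the step carries over from one core to the other, since there is only one readable example and nothing to compare it with.

The compounds shown leave open whether a phenethyl group on that same nitrogen would extend the step from phenyl to benzyl or reverse it. They also leave open whether an amine or a carboxylic acid on the benzyl ring would move the number further from that of compound 4, which gives 17300 nM.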